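Substituting the ring amine of compound 1

The source may report more compounds than this note shows. Statements on the series, on what has been measured and on what is new or still open speak of the compounds shown alone.

Among the compounds with values here, in a physicochemical assay for solubility, in phosphate buffer, at pH 7.4 (a higher number here means a more soluble compound, a lower number a less soluble compound), compound 1 `CC(C)n1cc(-c2ccnc3[nH]c(C4CCNCC4)cc23)ccc1=O` gives 910000 nM, level with compound 3 `CC(C)n1cc(-c2ccnc3[nH]c(C4CCN(CC(=O)N(C)C)CC4)cc23)cnc1=O` at 910000 nM, the two sharing the highest number so far. Compound 2 `CC(C)n1nc(-c2ccnc3[nH]c(C4CCN(CC(=O)N(C)C)CC4)cc23)ccc1=O` gives 11000 nM. Compound 4 `CC(C)n1cc(-c2ccnc3[nH]c(C4CCN(Cc5cccs5)CC4)cc23)ccc1=O` carries (thiophen-2-yl)methyl in place of hydrogen on an amine nitrogen in a ring. Within the data shown here, the only measured step, an 83-fold higher number from compound 2 to compound 3 (1.92 log units; beyond the scatter), is large, but it is a change on an aromatic carbon, so it bears only indirectly and shows how far one change can move this series. Among the measured compounds shown here, no measured step covers this nitrogen. With compound 1 at 910000 nM, a moderate downward step is expected in this assay. The estimated change is a 7.6-fold lower number from compound 1 to compound 4 (0.88 log units; beyond the scatter). Compound 4 is expected at 120000 nM, within 15000 nM to 700000 nM.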

Compound 4, solubility: 25000 nM
Compound 4: the middle estimate sits 4.8-fold (0.68 log units) above what was measured; the measured number falls inside the stated range.
By their numbers in this assay, from the lowest: compound 2; then compound 4; then compounds 1 and 3 (each within the scatter of the next).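

In this assay, within the data shown here, the amine nitrogen in the ring proves a sensitive position: (thiophen-2-yl)methyl in place of hydrogen gives a 36-fold lower number from compound 1 to compound 4 (1.56 log units; beyond the scatter), the first measured step at this nitrogen. Substitution here can therefore move the read-out by a large step, as a change on an aromatic carbon did in an 83-fold higher number from compound 2 to compound 3 (1.92 log units; beyond the scatter). Nothing available accounts for the size of this step.

Going by these compounds, it remains open whether the fall follows from the (thiophen-2-yl)methyl group itself or from any substituent on this nitrogen. Methyl, benzyl or a 2-hydroxyethyl chain on the core of compound 1 would separate these cases.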